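The compounds below may be only part of what the source reports. "The series", "measured", "known", "first", "only" and "open" are said of these compounds alone.

Compound 1 `COc1ccc(OC)c(C(=O)/C=C/c2ccco2)c1`: 10500 nM
Compound 2 `COc1ccc(OC)c(C(=O)/C=C/c2ccc(OC(=O)/C=C/c3ccc(C)cc3)cc2)c1`: 12600 nM

For the measured compounds named here, in a functional assay on MCF7 cells (Homo sapiens) for cytotoxicity, read by MTT assay (a higher number here means a weaker inhibitor, a lower number a stronger inhibitor), compound 2 gives 12600 nM, a number within the usual scatter of the one for compound 1 at 10500 nM. Compound 3 `COc1ccc(/C=C/C(=O)Oc2ccc(/C=C/C(=O)c3cc(OC)ccc3OC)cc2)cc1` carries methoxy in place of methyl on an aromatic carbon, para to a large group: methoxy in place of methyl on an aromatic carbon. Going by the values given here, no measured pair shows this change, so the expectation rests on compound 2 at 12600 nM, and no step beyond the scatter is expected in this assay. The expected change is a 1.1-fold lower number from compound 2 to compound 3 (0.06 log units; within the scatter), which stays within the scatter. Compound 3 is estimated at 11000 nM, with an expected range from 4500 nM to 26000 nM.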

Compound 3, half-maximal inhibitory concentration: 4100 nM
Compound 3: middle estimate off by 2.7-fold (0.43 log units), on the high side; the measured number lies below the stated range.
By their numbers in this assay, from the lowest: compound 3; then compounds 1 and 2 (each within the scatter of the next).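

In this assay, methoxy in place of methyl on this aromatic carbon, para to a large group, gives a 3.1-fold lower number from compound 2 to compound 3 (0.49 log units; beyond the scatter) and this modest step lies beyond the scatter. For the compounds shown here, this is the first evidence that the position responds to a change at all, as compound 1 and compound 2 do not differ in one place and could not show it. Nothing at hand explains the step.

The compounds shown leave open whether a hydroxyl or an amine on the same aromatic carbon would move the number further in the same direction. They also leave open whether a longer chain, such as ethoxy, would retain the step.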